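Fluoro for Methyl on a Fused Aromatic Core

The source may hold more compounds than are shown below. What is called first, only, known or untested is meant among the compounds shown, and "the series" means these compounds.

Measured compounds in an ADME assay on MT4 cells (Homo sapiens) for cytotoxicity, read by spectrophotometry, with a stated time of 5 days; on this read-out lower numbers stand for higher toxicity in this test and higher numbers for lower toxicity in this test:
Compound 1 `CCN(CC)CN1C(=O)/C(=N\NC(=S)NO)c2cc(F)ccc21` gives 521000 nM.
Compound 2 `CCn1cc(C(=O)O)c(=O)c2cc(F)c(N3CCN(CN4C(=O)/C(=N\NC(=S)NOC)c5cc(C)ccc54)CC3)cc21` gives 238000 nM.
Compound 3 `CCN(CC)CN1C(=O)/C(=N\NC(=S)NO)c2cc(C)ccc21` gives 534000 nM.

Compound 3 and compound 1 differ by fluoro in place of methyl on an aromatic carbon, and this change gave a 1.0-fold lower number from compound 3 to compound 1 (0.01 log units; within the scatter). Compound 2 carries a larger core; how it differs from compound 3 is not broken down here. Compound 4 `CCn1cc(C(=O)O)c(=O)c2cc(F)c(N3CCN(CN4C(=O)/C(=N\NC(=S)NOC)c5cc(F)ccc54)CC3)cc21` has not yet been measured. It differs from compound 2 by fluoro in place of methyl on an aromatic carbon, the same change, at the same place, as between compound 3 and compound 1. Since that change left the number essentially unchanged, compound 4 is expected to stand close to compound 2, with an estimated step of a 1.0-fold lower number from compound 2 to compound 4 (0.01 log units; within the scatter) in this assay. Compound 4 is therefore estimated at 230000 nM, between 120000 nM and 450000 nM.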

Compound 4, half-maximal cytotoxic concentration: 144000 nM
Beside the measured number, compound 4's estimate is 1.6-fold (0.20 log units) above it, and the stated range covers the measured number.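

In this assay, fluoro in place of methyl on an aromatic carbon gave a 1.7-fold lower number from compound 2 to compound 4 (0.22 log units; within the scatter), and this step agrees with the earlier one on the other core: the same change on two cores in this assay, a 1.0-fold lower number (0.01 log units; within the scatter) from compound 3 to compound 1 and a 1.7-fold lower number (0.22 log units; within the scatter) from compound 2 to compound 4, 1.6-fold (0.21 log units) apart, within the scatter of two such steps. Across these two pairs, the change therefore carried from one core to the other without a detectable difference. Within the data shown here, with only two pairs and one cytotoxicity read-out, this does not show that the change would behave alike on other cores or in any other test.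

The compounds shown leave open how chloro, methoxy or trifluoromethyl would stand on the same aromatic carbon. They also leave open what a longer chain, such as ethoxy, would do in place of the methoxy group of compound 4.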